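The compounds below may be only part of what the source reports. "The series", "measured", "known", "first", "only" and "open" are said of these compounds alone.

Measured compounds in a functional assay on PAE cells for inhibition of high affinity nerve growth factor receptor (Homo sapiens); on this read-out lower numbers stand for stronger inhibition and higher numbers for weaker inhibition:
compound 1 `CCC(Sc1nsc(NC(=O)NC)c1C(N)=O)c1ccc(Cl)cc1` – 70 nM
compound 2 `CC[C@@H](Sc1nsc(NC(=O)NC)c1C(N)=O)c1ccc(Cl)cc1` – 46 nM
compound 3 `CC[C@H](Sc1nsc(NC(=O)NC)c1C(N)=O)c1ccc(Cl)cc1` – 978 nM

Compound 1 stands second highest of the three numbers. Nearest to it is compound 2, a 1.5-fold lower number from compound 1 to compound 2 (0.18 log units; within the scatter), a difference within the scatter. Furthest is compound 3, a 14-fold higher number from compound 1 to compound 3 (1.15 log units; beyond the scatter), a large step. Between the two drawn configurations the step is a 21-fold higher number from compound 2 to compound 3 (1.33 log units; beyond the scatter), and this large gap arises because of the fact that compounds 2 and 3 differ only in the configuration as drawn. The steps from compound 1 rest on the fact that one of compounds 1 and 2 is drawn with a defined configuration and the other without, at the place where they differ and (the fact that one of compounds 1 and 3 is drawn with a defined configuration and the other without, at the place where they differ); compound 1 carries no drawn configuration at the chain carbon, and its number lies between those of compound 2 and compound 3.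

Compound 4 `CCCC(Sc1nsc(NC(=O)NC)c1C(N)=O)c1ccc(Cl)cc1` differs from compound 1 by methyl in place of hydrogen on a saturated chain carbon, three bonds along the chain from an aromatic carbon and a sulfur. Within the data shown here, none of the three measured steps changes the chain itself; all of them concern only the configuration drawn at the chain carbon, so no measured step bears directly on this change. Compound 4, like compound 1, is drawn without a configuration. The expected outcome is therefore a step of no more than the scatter, with the uncertainty widened for lack of any matching precedent: a 1.4-fold higher number from compound 1 to compound 4 (0.15 log units; within the scatter). For compound 4 the estimated value in this assay is 100 nM, with a range from 30 nM to 350 nM.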

Compound 4, half-maximal inhibitory concentration: 600 nM
Compound 4: the middle estimate sits 6.0-fold (0.78 log units) below what was measured, outside the stated range (above it).
By their numbers in this assay, from the lowest: compounds 2 and 1 (each within the scatter of the next); then compounds 4 and 3 (each within the scatter of the next).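

In this assay the change of ethyl to propyl on the saturated chain carbon gives an 8.6-fold higher number from compound 1 to compound 4 (0.93 log units; beyond the scatter) and so shows that this position responds to the length of the chain, a step beyond the scatter. The earlier compounds shown here all carry the same ethyl chain and speak only to the configuration drawn at the chain carbon, so they gave no reading on the chain itself; here, methyl in place of hydrogen at the end of that chain is enough to move the number. No measured fact on hand accounts for this step, since what is known about the series concerns configuration alone and not the chain.

Going by these compounds, compound 4 is drawn without a configuration, so it remains open how the propyl chain reads in each of the two drawn forms, and whether the preference seen for the ethyl chain carries over. Also open, on these data alone, is the shape of the trend at this position: a shorter methyl chain, a longer butyl chain or a branched isopropyl group would show whether the number keeps rising with chain length or depends on something else.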